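Swapping 1,2-dihydroxyethyl for ethylsulfonyl on a shared core

The source may hold more compounds than are shown below. What is called first, only, known or untested is meant among the compounds shown, and "the series" means these compounds.

Values in a physicochemical assay for lipophilicity, at pH 7.4 (a higher number here means a more lipophilic compound, a lower number a more polar compound), for the compounds measured so far
Compound 1 `C[C@H]1C(=O)N(C)C=Cc2cc(CC3CCOCC3)ccc21` gives 5.4
Compound 2 `C[C@H]1C(=O)N(C)C=Cc2cc(C(O)CO)ccc21` gives 1.1

Compound 2 holds the lower number of the two at 1.1 in this pair. Compound 3 `CCS(=O)(=O)c1ccc2c(c1)C=CN(C)C(=O)[C@@H]2C` has not been measured and carries ethylsulfonyl in place of 1,2-dihydroxyethyl on an aromatic carbon, which counts as ethylsulfonyl in place of 1,2-dihydroxyethyl on an aromatic carbon in all. Within the data shown here, the only measured guide is a number 4.30 log units lower from compound 1 to compound 2 (beyond the scatter) and it is large, yet its (oxan-4-yl)methyl group is absent from compound 3, so it bears only loosely. The expected move in this assay is a modest rise, a number 0.60 log units higher from compound 2 to compound 3 (beyond the scatter) as estimated here. The estimate for compound 3 is 1.7 (expected range 1 to 2.6).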

Compound 3, distribution coefficient: 3.1
The estimate for compound 3 lay 1.40 log units below the measured number, outside the stated range (above it).
By their numbers in this assay, from the lowest: compound 2; then compound 3; then compound 1.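

In this assay, the change gives a number 2.00 log units higher from compound 2 to compound 3 (beyond the scatter) and, measured against the other neighbour, a number 2.30 log units lower from compound 1 to compound 3 (beyond the scatter) so this position on the aromatic ring can also hold a group that lands well clear of both earlier numbers. Ethylsulfonyl has no hydrogen-bond donors, unlike 1,2-dihydroxyethyl, while their acceptor counts match. Nothing at hand accounts for the size of this step. The compounds shown leave open where an amine, a carboxylic acid or a longer chain on the sulfonyl would fall at this position.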